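Replacing 2-chloro-4-fluorophenyl with 2,4-dimethoxyphenyl

This account rests on a few compounds, and the source may have more. Where it says the series, first, only, none or still open, it means among the compounds named here.

In a functional assay on DU-145 cells (Homo sapiens) for inhibition, read by trypan blue exclusion, with a stated time of 96 h (on this read-out lower numbers stand for stronger inhibition of growth and higher numbers for weaker inhibition of growth), compound 1 `O=C(/C(=C\c1ccc(Br)cc1)S(=O)(=O)c1ccc(Br)cc1)c1ccc(Br)cc1` gives 10000 nM and compound 2 `O=C(/C(=C\c1ccc(F)cc1Cl)S(=O)(=O)c1ccc(Br)cc1)c1ccc(Br)cc1` gives 50000 nM as the higher of the two numbers, so compound 2 shows the weaker inhibition of growth. Among the compounds with values here, the only measured step is a 5.0-fold higher number from compound 1 to compound 2 (0.70 log units; beyond the scatter) and it falls at the same place as the change now in view. Compound 3 `COc1ccc(/C=C(\C(=O)c2ccc(Br)cc2)S(=O)(=O)c2ccc(Br)cc2)c(OC)c1` differs from compound 2 by 2,4-dimethoxyphenyl in place of 2-chloro-4-fluorophenyl on a double-bonded chain carbon bound to a double-bonded chain carbon in one place: 2,4-dimethoxyphenyl in place of 2-chloro-4-fluorophenyl on a double-bonded chain carbon bound to a double-bonded chain carbon. Within the data shown here, that single step shows that the number can move with this group, but no measured compound carries 2,4-dimethoxyphenyl, so the direction rests on thin evidence. With compound 2 at the top of a two-compound range, a partial return towards compound 1 at 10000 nM is the working expectation. Among the measured compounds shown here, the expected move is a 2.5-fold lower number from compound 2 to compound 3 (0.40 log units; beyond the scatter) and is taken as smaller than the one step seen so far. Compound 3 is estimated at 20000 nM with an expected range from 5000 nM to 70000 nM in this series.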

Compound 3, concentration for 50% growth inhibition: 8000 nM
For compound 3 the middle estimate is 2.5-fold (0.40 log units) above the measured one, and the stated range covers the measured number.
By their numbers in this assay, from the lowest: compounds 3 and 1 (each within the scatter of the next); then compound 2.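

In this assay, 2,4-dimethoxyphenyl at this place, on a double-bonded chain carbon bound to a double-bonded chain carbon, gives a 6.3-fold lower number from compound 2 to compound 3 (0.80 log units; beyond the scatter), so the weaker number of compound 2 is not shared by every replacement of 4-bromophenyl here. Compound 3 instead stands level with compound 1, at a 1.3-fold lower number from compound 1 to compound 3 (0.10 log units; within the scatter), which leaves compound 2 as the one clear outlier among the three compounds and shows that this place tolerates 2,4-dimethoxyphenyl, with its larger heavy-atom count and its 2 hydrogen-bond acceptors, as well as 4-bromophenyl in this read-out. No measurement at hand accounts for the difference between 2-chloro-4-fluorophenyl and 2,4-dimethoxyphenyl.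

These three compounds do not separate the contribution of the chlorine from that of the fluorine in 2-chloro-4-fluorophenyl, nor that of one methoxy group from the other in 2,4-dimethoxyphenyl. As far as these compounds go, whether a phenyl group bearing a dimethylamino group or a carboxylic acid would stay level with compound 1 and compound 3, or fall towards compound 2, also remains open.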